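From fluoro to methoxy: compound 2 and compound 4

The compounds below may be only part of what the source reports. "The series", "measured", "known", "first", "only" and "open" are said of these compounds alone.

Measured values in a functional assay on MCF7 cells (Homo sapiens) for inhibition, read by MTT assay, with a stated time of 24 h (a lower number here means a stronger inhibitor, a higher number a weaker inhibitor), are as follows:
Compound 1 `O=C1CSC(c2c[nH]nc2-c2ccc(Cl)cc2)N1n1c(S)nnc1COc1cccc2ccccc12` gives 100 ug/mL
Compound 2 `O=C1CSC(c2c[nH]nc2-c2ccc(F)cc2)N1n1c(S)nnc1COc1ccccc1` gives 30 ug/mL
Compound 3 `Cc1ccc(OCc2nnc(S)n2N2C(=O)CSC2c2c[nH]nc2-c2ccc(F)cc2)cc1` gives > 100 ug/mL as a limit of the assay, not a number

Compound 2 has the lower of the two numerical values, and compound 1 lies higher by a gap beyond the scatter. Compound 4 `COc1ccc(-c2n[nH]cc2C2SCC(=O)N2n2c(S)nnc2COc2ccccc2)cc1` differs from compound 2 by methoxy in place of fluoro on an aromatic carbon (methoxy in place of fluoro on an aromatic carbon, para to a large group). For the measured compounds named here, no measured step makes this exchange. The nearest evidence is an at least 3.3-fold higher number from compound 2 to compound 3 (0.52 log units; beyond the scatter) (methyl in place of hydrogen on an aromatic carbon, at another site). On that thin basis, a 1.7-fold higher number from compound 2 to compound 4 (0.22 log units; within the scatter) is expected in this assay as a modest move to a higher number. Compound 4 is estimated at 50 ug/mL (expected range 15 ug/mL to 120 ug/mL).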

Compound 4, half-maximal inhibitory concentration: 85 ug/mL
Estimate against measurement, compound 4: 1.7-fold (0.23 log units) below; the measured number falls inside the stated range.
By their numbers in this assay, from the lowest: compound 2; then compounds 4 and 1 (each within the scatter of the next).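

In this assay, for the compounds shown here, the earlier compounds gave no single-change step at this position; exchanging 4-fluorophenyl for 4-methoxyphenyl now gives a 2.8-fold higher number from compound 2 to compound 4 (0.45 log units; beyond the scatter). The position therefore responds to this change with the rest of compound 2 held constant. Both single changes shown from compound 2, this one and the methyl step at another site, lead to a higher number.

As far as these compounds go, how an amine or a nitrile in place of fluoro would read remains open, including whether any group here gives a lower number than compound 2. Upward, readings in this series end at a ceiling: the limit of > 100 ug/mL in this assay, at which 1 of the 4 values shown sits.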